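Shortening the Linker in a Sulfonamide Series

This account rests on a few compounds, and the source may have more. Where it says the series, first, only, none or still open, it means among the compounds named here.

Compound 1 `O=S(=O)(NCCCNc1nccc(-c2c(-c3cccc(F)c3)nc3sccn23)n1)c1ccc(Br)cc1`: 9400 nM
Compound 2 `O=S(=O)(NCCCNc1nccc(-c2c(-c3cccc(F)c3)nc3sccn23)n1)c1ccccc1`: 6850 nM
Compound 3 `O=C(NCCCNc1nccc(-c2c(-c3cccc(F)c3)nc3sccn23)n1)c1ccc(Cl)cc1`: > 20000 nM
Compound 4 `O=S(=O)(NCCNc1nccc(-c2c(-c3cccc(F)c3)nc3sccn23)n1)c1ccc(Cl)cc1`: not yet measured

Of the compounds shown here, three sharing the core of compound 1 have been measured in a functional assay on SK-MEL-28 cells (Homo sapiens) for cytotoxicity, read by MTT assay; a lower number here means a stronger inhibitor, a higher number a weaker inhibitor. Compound 1 gives 9400 nM, the higher of the two plain numbers. Compound 2 gives 6850 nM, and a 1.4-fold lower number from compound 1 to compound 2 (0.14 log units; within the scatter). For compound 3 the assay reports only a limit, > 20000 nM, which is the limit of > 20000 nM in this assay, at which 1 of the 3 values shown sits. The two steps toward it, an at least 2.1-fold higher number from compound 1 to compound 3 (0.32 log units; beyond the scatter) and an at least 2.9-fold higher number from compound 2 to compound 3 (0.46 log units; beyond the scatter), are the only ones beyond the scatter, and both involve exchanging the sulfonyl for a carbonyl.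

Compound 4 differs from compound 1 by ((4-chlorophenyl)sulfonyl)amino in place of (((4-bromophenyl)sulfonyl)amino)methyl on a saturated chain carbon, two bonds along the chain from a nitrogen on an aromatic ring. Among the compounds with values here, the shortening of the chain has no measured counterpart here, so that part of the change is untested. The halogen swap is a smaller alteration than the one in a 1.4-fold lower number from compound 1 to compound 2 (0.14 log units; within the scatter), which stayed within the scatter, and the sulfonyl is retained. Compound 4 is therefore expected to give about 9000 nM, with a range from 3000 nM to 25000 nM. The expected step is a 1.0-fold lower number from compound 1 to compound 4 (0.02 log units; within the scatter).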

Compound 4, half-maximal inhibitory concentration: 18600 nM
For compound 4 the middle estimate is 2.1-fold (0.32 log units) below the measured one, and the stated range covers the measured number.
By their numbers in this assay, from the lowest: compounds 2, 1 and 4 (each within the scatter of the next, the first and the last beyond it). At a limit, above all of these: compound 3.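

Within the data shown here, with the sulfonyl kept, this change at the saturated chain carbon still moves the result in this assay, with a 2.7-fold higher number from compound 2 to compound 4 (0.43 log units; beyond the scatter), whereas the earlier steps beyond the scatter all exchanged the sulfonyl for a carbonyl. Against the bromo compound the same kind of change gives a 2.0-fold higher number from compound 1 to compound 4 (0.30 log units; within the scatter). The remaining step is an at least 1.0-fold lower number from compound 3 to compound 4 (0.03 log units; that floor lies within the scatter), which is only a floor whose real size cannot be read. Compound 3 stands at a limit: the limit of > 20000 nM in this assay, at which 1 of the 4 values shown sits.

As far as these compounds go, the shorter chain and the chloro group enter together here, so their separate contributions remain unknown. Also open, from the compounds shown here alone, are how a longer chain would behave and whether an amine in place of the sulfonamide would be tolerated on the shorter chain.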